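The compounds below may be only part of what the source reports. "The series", "measured", "known", "first", "only" and "open" are said of these compounds alone.

Compound 1 `O=C(Nc1cccc(-n2cc(-c3ccncc3)c(-c3ccc(Cl)c(O)c3)n2)c1)Nc1cccc(C(F)(F)F)c1` gives in a functional assay on TK-10 cells (Homo sapiens) for inhibition, read by sulforhodamine B assay, with a stated time of 48 h (a lower number here means that less compound is tolerated, a higher number that more compound is tolerated), a limit of the assay, not a number, > 32500 nM. Compound 2 `COc1cc(-c2nn(-c3cccc(NC(=O)c4cccc(C(F)(F)F)c4)c3)cc2-c2ccncc2)ccc1Cl` gives in this assay a limit of the assay, not a number, > 50000 nM.

Compound 2 therefore stands at the limit of > 50000 nM in this assay, at which 1 of the 2 values shown sits, and nothing beyond that limit is known of it. Compound 3 `COc1cc(-c2nn(-c3cccc(NC(=O)c4ccc(Cl)c(C(F)(F)F)c4)c3)cc2-c2ccncc2)ccc1Cl` differs from compound 2 by chloro in place of hydrogen on an aromatic carbon. Among the measured compounds shown here, no measured step is available for this change, so no step beyond the scatter is expected in this assay. The step this estimate implies is expected to be a number no higher from compound 2 to compound 3 (the limit leaves the size open). Compound 3 is estimated at 50000 nM, between 20000 nM and 100000 nM, most likely again as a limit.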

Compound 3, concentration lethal to 50% of the cells: > 32500 nM
Compound 3 gave a limit, no number; the forecaster's own chance of this, stated with the estimate: 80%; the middle value does not contradict the limit.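

Among the compounds shown here, compound 2 and compound 3 both gave only limits of the assay, not numbers, so no step between them can be read in this assay. The compounds shown leave open where any true value lies and whether chloro in place of hydrogen shifts it.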